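Cytotoxicity notes on a furanone-triazole pair

The source may hold more compounds than are shown below. What is called first, only, known or untested is meant among the compounds shown, and "the series" means these compounds.

Measured so far:
compound 1, `Cc1ccc(-c2cn(C/C=C3\OC(=O)C(OCc4ccccc4)=C3OCc3ccccc3)nn2)cc1`: > 100000 nM
compound 2, `O=C1O[C@H]([C@@H](O)Cn2cc(-c3cccc(O)c3)nn2)C(OCc2ccccc2)=C1OCc1ccccc1`: 39000 nM

Among the compounds with values here, in an ADME assay on HFF cells (Homo sapiens) for cytotoxicity, read by MTT assay, with a stated time of 72 h (on this read-out lower numbers stand for stronger inhibition and higher numbers for weaker inhibition), compound 2 gives 39000 nM, the only number in hand. For compound 1 the read-out is a limit of the assay, > 100000 nM; it is the case described by the limit of > 100000 nM in this assay, at which 1 of the 2 values shown sits.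

Compound 3, `CCCCCc1ccc(-c2cn(C[C@H](O)[C@H]3OC(=O)C(OCc4ccccc4)=C3OCc3ccccc3)nn2)cc1`, is not yet measured. Its change from compound 2 is 4-pentylphenyl in place of 3-hydroxyphenyl on an aromatic carbon. Within the data shown here, no measured step of this kind exists, so the direction is open; a step toward lower numbers in this assay, small and close to the scatter, is expected for compound 3. The estimate for compound 3 is 25000 nM, within 8000 nM to 80000 nM, the step from compound 2 to compound 3 expected as a 1.6-fold lower number from compound 2 to compound 3 (0.19 log units; within the scatter).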

Compound 3, half-maximal inhibitory concentration: > 100000 nM
Compound 3 gave a limit, no number; the forecaster's own chance of this, stated with the estimate: 15%; middle value at least 4.0-fold (0.60 log units) away from the limit.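

In this assay, 4-pentylphenyl in place of 3-hydroxyphenyl on this aromatic carbon gives an at least 2.5-fold higher number from compound 2 to compound 3 (0.40 log units; beyond the scatter), the first step read at this position, and it runs toward weaker inhibition. The size of the step is only a lower bound, since compound 3 reads as a limit and not a number: the limit of > 100000 nM in this assay, at which 2 of the 3 values shown sit.

The compounds shown do not separate the loss of the hydroxyl from the gain of the pentyl chain. On these data alone, how an amine or a carboxylic acid on this phenyl ring would read remains open.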